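A Methyl on the Fused Ring of Compound 2

The compounds below may be only part of what the source reports. "The series", "measured", "known", "first", "only" and "open" are said of these compounds alone.

In a functional assay on cells (Cancer cell lines, Homo sapiens) for cytotoxicity, read by sulforhodamine B assay, with a stated time of 48 h (on this read-out higher numbers stand for weaker inhibition of growth and lower numbers for stronger inhibition of growth), compound 2 `O=C1N=C(N2N=C(c3ccccc3)CC2c2ccc(Cl)cc2)S/C1=C1/C(=O)Nc2ccccc21` gives 850 nM, the lower of the two numbers measured. Compound 1 `COc1ccc(C2CC(c3ccccc3)=NN2C2=NC(=O)/C(=C3\C(=O)Nc4ccccc43)S2)cc1` gives 4270 nM in this assay, and the step of a 5.0-fold lower number from compound 1 to compound 2 (0.70 log units; beyond the scatter) went with a chloro in place of methoxy on an aromatic carbon. Among the compounds with values here, compound 3 `Cc1ccc2c(c1)/C(=C1\SC(N3N=C(c4ccccc4)CC3c3ccc(Cl)cc3)=NC1=O)C(=O)N2` carries methyl in place of hydrogen on an aromatic carbon, a change at a different place from the one measured step, so no measured step bears on it. A shift no larger than the scatter is therefore expected, no change at the digits printed from compound 2 to compound 3 (within the scatter). Compound 3 is expected to give 850 nM, within 400 nM to 1800 nM.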

Compound 3, concentration for total growth inhibition: 520 nM
Estimate against measurement, compound 3: 1.6-fold (0.21 log units) above, within the range that was stated.
By their numbers in this assay, from the lowest: compounds 3 and 2 (each within the scatter of the next); then compound 1.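

In this assay, methyl in place of hydrogen on an aromatic carbon of a six-membered aromatic ring of carbon only went with a 1.6-fold lower number from compound 2 to compound 3 (0.21 log units; within the scatter), so at this position, which the earlier step did not touch, the added methyl produced no difference that the assay can separate from scatter. Within the data shown here, this is the first reading at this ring position, and it shows that the position accepts a methyl. No supporting measurement bears on this result. On these data alone, whether an amine or a carboxylic acid at the same carbon would also stay within the scatter remains open.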